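The source may hold more compounds than are shown below. What is called first, only, known or untested is meant among the compounds shown, and "the series" means these compounds.

Series notes. Compound 1 `COc1ccc(-n2c(SCc3ccc(F)cc3)nnc2-c2cc(OC)c(OC)c(OC)c2)cc1` gives 35000 nM in a functional assay on HepG2 cells (Homo sapiens) for inhibition, read by MTT assay, with a stated time of 48 h; a higher number here means a weaker inhibitor, a lower number a stronger inhibitor. Compound 2 `COc1ccc(-n2c(SCC(=O)c3ccccc3)nnc2-c2cc(OC)c(OC)c(OC)c2)cc1` carries benzoyl in place of 4-fluorophenyl on a saturated chain carbon bound to a sulfur and in this assay compound 2 gives 16200 nM; the step is a 2.2-fold lower number from compound 1 to compound 2 (0.33 log units; beyond the scatter). Compound 3 `COc1cc(-c2nnc(SCc3ccc(F)cc3)n2-c2ccc(N(C)C)cc2)cc(OC)c1OC` differs from compound 1 by dimethylamino in place of methoxy on an aromatic carbon, and in this assay compound 3 gives 26400 nM, a step of a 1.3-fold lower number from compound 1 to compound 3 (0.12 log units; within the scatter). Compound 4 `COc1cc(-c2nnc(SCC(=O)c3ccccc3)n2-c2ccc(N(C)C)cc2)cc(OC)c1OC` is not yet measured; it carries benzoyl in place of 4-fluorophenyl on a saturated chain carbon bound to a sulfur, the same change as in compound 2, since the place lines agree word for word, but on the core of compound 3, which differs from the core of compound 1 by dimethylamino in place of methoxy on an aromatic carbon. Compound 4 is expected to show a step of a 2.0-fold lower number from compound 3 to compound 4 (0.31 log units; beyond the scatter) in this assay, resting on compound 2 and the step of a 2.2-fold lower number from compound 1 to compound 2 (0.33 log units; beyond the scatter). The estimate for compound 4 is 13000 nM, with a range from 6000 nM to 28000 nM, pending measurement.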

Compound 4, half-maximal inhibitory concentration: 18900 nM
Estimate against measurement, compound 4: 1.5-fold (0.16 log units) below; the range from low to high includes it.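

In this assay, benzoyl in place of 4-fluorophenyl on the core of compound 3 gives a 1.4-fold lower number from compound 3 to compound 4 (0.15 log units; within the scatter), and this step agrees with the earlier one on the core of compound 1: the same change on two cores in this assay, a 2.2-fold lower number (0.33 log units; beyond the scatter) from compound 1 to compound 2 and a 1.4-fold lower number (0.15 log units; within the scatter) from compound 3 to compound 4, 1.5-fold (0.19 log units) apart, within the scatter of two such steps. Dimethylamino in place of methoxy on an aromatic carbon, read on the benzoyl compounds, gives a 1.2-fold higher number from compound 2 to compound 4 (0.07 log units; within the scatter), and this change also carries over: the same change on two cores in this assay, a 1.3-fold lower number (0.12 log units; within the scatter) from compound 1 to compound 3 and a 1.2-fold higher number (0.07 log units; within the scatter) from compound 2 to compound 4, 1.5-fold (0.19 log units) apart, within the scatter of two such steps. Within these four compounds the two changes combine with no detectable interaction, but that rests on only two cores, and the new steps alone do not establish a real benzoyl or dimethylamino effect on the cores where they were read.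

As far as these compounds go, whether this agreement extends to other groups remains open, for example a carboxylic acid or a longer chain in place of benzoyl on a saturated chain carbon bound to a sulfur. A morpholine in place of dimethylamino on an aromatic carbon is equally untested by the compounds shown.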